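Carboxy in Place of Hydroxymethyl on the Shared Core

The source may hold more compounds than are shown below. What is called first, only, known or untested is meant among the compounds shown, and "the series" means these compounds.

Compound 1, `C=CC(=O)Nc1ccc(Cn2nc(-c3ccc(Oc4ccccc4)cc3)cc2C(=O)O)cc1`, gives > 60000 nM in a functional assay on Maver1 cells (Homo sapiens) for inhibition, read by luminescence and CellTiter-Glo, with a stated time of 72 h; a higher number here means a weaker inhibitor, a lower number a stronger inhibitor; this is a limit of the assay, not a number.
Compound 2, `O=C(CCl)Nc1ccc(Cn2nc(-c3ccc(Oc4ccccc4)cc3)cc2C(=O)O)cc1`, gives 1200 nM.
Compound 3, `O=C(CCl)Nc1cccc(Cn2nc(-c3ccc(Oc4ccccc4)cc3)cc2CO)c1`, gives 400 nM.

Of the two numbers recorded, compound 3 has the lowest; its nearest neighbour is compound 2, whose number is higher by an amount beyond the usual scatter. Within the data shown here, the one measured step, an at least 50-fold lower number from compound 1 to compound 2 (1.69 log units; beyond the scatter), concerns the group on the carbonyl carbon and does not touch the part of the molecule that changes here. Among the measured compounds shown here, compound 2 and compound 3 differ in two places at once, so their two values show only that the hydroxymethyl compound with the chloroacetamide on the other ring position sits lower than the carboxy compound.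

Compound 4, `O=C(CCl)Nc1cccc(Cn2nc(-c3ccc(Oc4ccccc4)cc3)cc2C(=O)O)c1`, has not yet been measured. It differs from compound 3 as follows: carboxy in place of hydroxymethyl on an aromatic carbon. For the measured compounds named here, no measured step bears directly on this exchange, so the expectation rests on the carboxy compound 2 and the hydroxymethyl compound 3 sitting within a modest distance of each other.

For compound 4 in this assay, a number near 700 nM is expected, between 250 nM and 2500 nM, which means an expected step of a 1.8-fold higher number from compound 3 to compound 4 (0.24 log units; within the scatter), not clearly beyond the scatter.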

Compound 4, half-maximal inhibitory concentration: 4700 nM
For compound 4 the middle estimate is 6.7-fold (0.83 log units) below the measured one, outside the stated range (above it).
By their numbers in this assay, from the lowest: compound 3; then compound 2; then compound 4. At a limit, above all of these: compound 1.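

With the 3-(((chloromethyl)carbonyl)amino)phenyl group held fixed, the group on the aromatic carbon next to the ring nitrogen can now be read on its own, and in this assay the exchange gives a 12-fold higher number from compound 3 to compound 4 (1.07 log units; beyond the scatter), so hydroxymethyl and carboxy are far from interchangeable at this position. With carboxy held fixed, the point at which the chloroacetamide nitrogen sits on the phenyl ring also counts, though the change is modest: a 3.9-fold higher number from compound 2 to compound 4 (0.59 log units; beyond the scatter). Compound 1 remains a limit of the assay and not a number, and its exchange changes both the group on the carbonyl carbon and that attachment point, so an at least 12-fold lower number from compound 1 to compound 4 (1.10 log units; beyond the scatter) gives only a bound: the limit of > 60000 nM in this assay, at which 1 of the 4 values shown sits.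

Still open is whether hydroxymethyl gives a similar step when paired with the 4-(((chloromethyl)carbonyl)amino)phenyl group, since the compounds shown cover this exchange on only one side. Also open, going by these compounds, is how a primary amide or a methyl ester would read at the same position, and these values alone give no reason for the size of the step.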